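Swapping methyl for methoxy on an aromatic carbon

The source may report more compounds than this note shows. Statements on the series, on what has been measured and on what is new or still open speak of the compounds shown alone.

- compound 1 `O=[N+]([O-])c1ccc(Nc2nnc(-c3c[nH]c4ccccc34)o2)cc1` gives 1760 nM as measured
- compound 2 `Cc1ccc(Nc2nnc(-c3c[nH]c4ccccc34)o2)cc1` gives 15800 nM as measured
- compound 3 `COc1ccc(Nc2nnc(-c3c[nH]c4ccccc34)o2)cc1` has no measurement yet

Both numbers come from a functional assay on HeLa cells (Homo sapiens) for inhibition, read by MTT assay, with a stated time of 72 h (on this read-out higher numbers stand for weaker inhibition and lower numbers for stronger inhibition), and compound 2, at 15800 nM, holds the higher one, which makes it the weaker inhibitor of the pair. Compound 3 keeps the shared core and differs at one place: methoxy in place of methyl on an aromatic carbon. For the measured compounds named here, only one measured step bears on this, and only loosely. It is a 9.0-fold higher number from compound 1 to compound 2 (0.95 log units; beyond the scatter) for methyl in place of nitro, a modest change beyond the scatter. Going by the values given here, that step shows that this place on the ring can matter, but it says nothing about methoxy, and no measured compound carries that group. A small step is therefore expected, with no firm direction. The estimate is a 1.4-fold lower number from compound 2 to compound 3 (0.16 log units; within the scatter) and is expected to stay within the scatter. For compound 3 the expected value is 11000 nM with an estimated range of 4000 nM to 30000 nM in this test.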

Compound 3, half-maximal inhibitory concentration: 5820 nM
The estimate for compound 3 lay 1.9-fold (0.28 log units) above the measured number; the measured number falls inside the stated range.
By their numbers in this assay, from the lowest: compound 1; then compound 3; then compound 2.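

Placing methoxy on this aromatic carbon, para to a large group, gives a 2.7-fold lower number from compound 2 to compound 3 (0.43 log units; beyond the scatter) in this assay, a modest step toward stronger inhibition. The earlier pair showed only that nitro and methyl give different numbers at this place, and this result adds a third group that also differs from both of them: putting methoxy in place of nitro gives a 3.3-fold higher number from compound 1 to compound 3 (0.52 log units; beyond the scatter), again a modest step beyond the scatter. Compound 3 therefore falls between compound 1 and compound 2, so this single place separates all three groups shown, and the swap from methyl to methoxy, which adds one oxygen, is enough to move the number; nothing measured here explains why these steps have the sizes they do.

Three groups at one place cannot show how the number would respond to an amine, a carboxylic acid or a longer chain such as ethoxy in the same spot. The compounds shown also leave open whether the same order of these three groups would hold if the shared core were changed elsewhere.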